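Cytotoxicity notes on a diarylpyrimidine series: chloropropyl analogue

This account rests on a few compounds, and the source may have more. Where it says the series, first, only, none or still open, it means among the compounds named here.

Measured so far in an ADME assay on MT4 cells (Homo sapiens) for cytotoxicity, read by MTT assay, with a stated time of 5 days; a lower number here means that less compound is tolerated, a higher number that more compound is tolerated:
- compound 1 `CN(c1ccnc(Nc2ccc(C#N)cc2)n1)c1c(F)cc(-c2ccc(C#N)cc2)cc1F`: 148000 nM
- compound 2 `CCCN(c1ccnc(Nc2ccc(C#N)cc2)n1)c1c(F)cc(-c2ccc(C#N)cc2)cc1F`: 212000 nM
- compound 3 `N#Cc1ccc(Nc2nccc(N(CCCO)c3c(F)cc(-c4ccc(C#N)cc4)cc3F)n2)cc1`: 68000 nM

Within this set compound 1 holds the second highest number of the three; it sits nearest compound 2 and furthest from compound 3.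

The new member is compound 4 `N#Cc1ccc(Nc2nccc(N(CCCCl)c3c(F)cc(-c4ccc(C#N)cc4)cc3F)n2)cc1`. Relative to compound 1 the change is 2-chloroethyl in place of hydrogen on a saturated chain carbon bound to a nitrogen on an aromatic ring.

Among the measured compounds shown here, three measured steps touch the same chain. Extending the chain alone gave a 1.4-fold higher number from compound 1 to compound 2 (0.16 log units; within the scatter), with no movement beyond the scatter. Placing a donor-bearing group there gave a 2.2-fold lower number from compound 1 to compound 3 (0.34 log units; beyond the scatter), and the same comparison against the plain propyl chain gave a 3.1-fold lower number from compound 2 to compound 3 (0.49 log units; beyond the scatter). The chloro chain carries no donor and no acceptor, so it is expected to track compound 2 more closely than compound 3, leaving a 1.0-fold higher number from compound 1 to compound 4 (0.01 log units; within the scatter) as the expected step in this assay, with no movement beyond the scatter anticipated.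

Compound 4 is therefore estimated at 150000 nM, with a range from 70000 nM to 320000 nM.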

Compound 4, half-maximal cytotoxic concentration: > 250000 nM
Compound 4 ended at the assay's limit; the forecaster's own chance of this, stated with the estimate: 10%; at least 1.6-fold (0.22 log units) between middle value and limit.
By their numbers in this assay, from the lowest: compound 3; then compounds 1 and 2 (each within the scatter of the next). At a limit, above all of these: compound 4.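

In this assay compound 4 stands at a limit of the assay and not at a number: the limit of > 250000 nM in this assay, at which 1 of the 4 values shown sits.

Chloro in place of hydroxy at the chain end gives an at least 3.6-fold higher number from compound 3 to compound 4 (0.56 log units; beyond the scatter), so a three-carbon chain does not by itself carry the lower number of compound 3, and among the four compounds only the hydroxy chain stands apart from all the others. Against the other two chains the limit separates nothing yet: the readings are an at least 1.6-fold higher number from compound 1 to compound 4 (0.22 log units; that floor lies within the scatter) and an at least 1.1-fold higher number from compound 2 to compound 4 (0.07 log units; that floor lies within the scatter), and both floors leave compound 4 unresolved from compound 1 and compound 2.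

On these data alone, whether an amine or a carboxylic acid at the chain end would follow the hydroxy chain of compound 3 or the chloro chain of compound 4 stays open. So does the reading for a longer chain ending in chloro, and how far compound 4 lies past its limit.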